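Dichloroacetanilides on Bel-7402 cells: from fluoro to trifluoromethylsulfanyl

The source may hold more compounds than are shown below. What is called first, only, known or untested is meant among the compounds shown, and "the series" means these compounds.

The series rests on a dichloroacetamide attached to an anilide. Compound 1, `O=C(Nc1cccc(F)c1)C(Cl)Cl`, carries a fluoro group on the aromatic ring; in a functional assay on Bel-7402 cells (Homo sapiens) for antiproliferative activity, read by MTT assay, with a stated time of 72 h (on this read-out higher numbers stand for weaker inhibition and lower numbers for stronger inhibition), compound 1 is recorded as "not determined" (no result reported), so no number describes where it stands, and it serves here only as the structural starting point. Within the data shown here, the one measured member is compound 2, `N#Cc1cccc(NC(=O)C(Cl)Cl)c1`, which bears a nitrile in place of the fluoro; in this assay compound 2 gives 48400 nM, a weak inhibition. Among the measured compounds shown here, no step between two measured compounds is available, so nothing about size or direction of change can be read from the numbers themselves.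

Compound 3, `O=C(Nc1cccc(SC(F)(F)F)c1)C(Cl)Cl`, has not yet been measured. It differs from compound 1 by (trifluoromethyl)sulfanyl in place of fluoro on an aromatic carbon. For the measured compounds named here, with compound 1 lacking a value, the only anchor is compound 2 and its 48400 nM; the account can expect no step beyond the scatter in this assay and can only place compound 3 in the same weak range. Compound 3 is therefore estimated at 25000 nM, with a range from 6000 nM to 100000 nM.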

Compound 3, half-maximal inhibitory concentration: 6540 nM
Beside the measured number, compound 3's estimate is 3.8-fold (0.58 log units) above it; the range from low to high includes it.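

In this assay, among these compounds, the swap of cyano for (trifluoromethyl)sulfanyl gives a 7.4-fold lower number from compound 2 to compound 3 (0.87 log units; beyond the scatter) and so provides the first readable step, showing that the number at this place on the aromatic ring responds to the group it carries. The step runs towards stronger inhibition and lies beyond the scatter, while the rest of the molecule stays the same, but the step from compound 1 to compound 3 cannot be read, as compound 1 has no value. Nothing given here bears on why this change goes with a lower number.

Among the compounds shown here, with only two values in hand, a single step marks one direction between two groups and sets no trend, so it remains open how an amine, a carboxylic acid or a longer chain such as an ethylsulfanyl group would read at this same place. On these data alone, it is equally open whether (trifluoromethyl)sulfanyl would give a similar number on another carbon of the ring, and whether the step would hold if the dichloroacetamide were replaced by a plain acetamide.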